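The compounds below may be only part of what the source reports. "The series", "measured", "known", "first", "only" and "open" are said of these compounds alone.

Working notes on the series. In a functional assay on MCF7 cells (Homo sapiens) for cytotoxicity, read by MTT assay, with a stated time of 72 h (a lower number here means a stronger inhibitor, a higher number a weaker inhibitor), compound 3 `CN(C)c1ccc(/C=C2\S/C(=N\c3nc(-c4ccc(Cl)cc4)cs3)NC2=O)cc1` gives 100 nM, the lowest number among the two results, with compound 1 `COc1ccc(/C=C2\S/C(=N\c3csc(-c4ccc(Cl)cc4)c3)NC2=O)cc1OC` next at 7600 nM, a gap well beyond the scatter; for compound 2 `COc1cccc(N2C(=O)CS/C2=N\c2csc(-c3ccccc3)c2)c1` the entry reads "not determined" (no result reported), so no result was reported. Compound 4 `COc1ccc(/C=C2\S/C(=N\c3nc(-c4ccc(Cl)cc4)cs3)NC2=O)cc1` is to be measured in this assay. The change from compound 3 to compound 4 is methoxy in place of dimethylamino on an aromatic carbon. Within the data shown here, no step between measured compounds covers this exchange, so the expectation rests only on the position of compound 3 at 100 nM. A loss beyond the scatter is expected, with the step from compound 3 to compound 4 estimated at a 5.0-fold higher number from compound 3 to compound 4 (0.70 log units; beyond the scatter). For compound 4 the estimate in this assay is 500 nM, within 150 nM to 3000 nM.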

Compound 4, half-maximal inhibitory concentration: 100 nM
The estimate for compound 4 lay 5.0-fold (0.70 log units) above the measured number; the measured number lies below the stated range.
By their numbers in this assay, from the lowest: compounds 3 and 4 (each within the scatter of the next); then compound 1.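

In this assay, methoxy in place of dimethylamino on an aromatic carbon, para to a large group, gives no change at the digits printed from compound 3 to compound 4 (within the scatter). This position therefore accepts either group without a change beyond the scatter, so dimethylamino is not required for the number seen with compound 3. No available measurement explains this equivalence. The compounds shown leave open how a carboxylic acid, a primary amine or a longer alkoxy chain would read at this position. Compound 1 differs from compound 4 in more than one place, so it does not settle this.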